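A few compounds are considered here, and "the series" means these few. Any claim that something is new, unique, unknown or untested is made for them only; others in the source may bear on it.

Measured in a functional assay on A549 cells (Homo sapiens) for antiproliferative activity, read by sulforhodamine B assay, with a stated time of 72 h; on this read-out higher numbers stand for weaker inhibition and lower numbers for stronger inhibition:
Compound 1 `COc1cccc(/C=C2\CCC=CC2=O)c1`: 1480 nM
Compound 2 `COc1ccc(/C=C2\CCC=CC2=O)cc1OC`: 4680 nM

Compound 2 stands at 4680 nM and so holds the higher of the two numbers, the weaker inhibition of the pair. Compound 3 `CCOc1ccc(/C=C2\CCC=CC2=O)cc1OC` has not yet been measured. It differs from compound 2 as follows: methyl in place of hydrogen on a saturated chain carbon bound to an oxygen on an aromatic ring (methyl in place of hydrogen on a saturated chain carbon bound to an oxygen on an aromatic ring, which turns methoxy to ethoxy).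

Among the compounds with values here, only one measured step bears on this change: a 3.2-fold higher number from compound 1 to compound 2 (0.50 log units; beyond the scatter) when methoxy took the place of hydrogen on an aromatic carbon. That step is modest and is a different change, so it guides the expectation only loosely. Here a methyl alone is added to an existing methoxy, so a step no larger is expected in this assay, most likely slightly upward or none beyond the scatter. The expected step is a 1.2-fold higher number from compound 2 to compound 3 (0.07 log units; within the scatter) and this remains an estimate. For compound 3 the estimated value is 5500 nM, with an expected range from 2200 nM to 13000 nM.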

Compound 3, half-maximal inhibitory concentration: 3640 nM
For compound 3 the middle estimate is 1.5-fold (0.18 log units) above the measured one; measured number inside the range.
By their numbers in this assay, from the lowest: compound 1; then compounds 3 and 2 (each within the scatter of the next).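

In this assay the methoxy group at this place tolerates growth to ethoxy: adding a methyl on the saturated chain carbon bound to an oxygen on an aromatic ring gives a 1.3-fold lower number from compound 2 to compound 3 (0.11 log units; within the scatter) and so makes no difference that can be told from the usual scatter. The earlier compounds shown here showed only what happens when a group replaces hydrogen on an aromatic carbon, and compound 3 now adds that ethoxy in place of that hydrogen gives a 2.5-fold higher number from compound 1 to compound 3 (0.39 log units; beyond the scatter), so compound 1 still keeps its distance from the ethoxy compound as it did from the methoxy compound. Nothing measured here explains why the extra methyl leaves the number so little moved, or why both compounds stay apart from compound 1.

The compounds shown leave open whether a longer chain such as propoxy or butoxy, or a hydroxyl or an amine in the same place, would keep the number level with compound 2 and compound 3 or shift it. They also leave open whether this tolerance of ethoxy carries over to other cell lines.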